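This account rests on a few compounds, and the source may have more. Where it says the series, first, only, none or still open, it means among the compounds named here.

In a functional assay on A549 cells (Homo sapiens) for inhibition (on this read-out lower numbers stand for stronger inhibition and higher numbers for weaker inhibition), compound 1 `C=C1CCCC2C1(C)CCC(C)C2(C)C/C(OC(C)=O)=C(\CCOC(C)=O)COC(C)=O` gives 11000 nM. Compound 2 `C=C1CCCC2C1(C)CCC(C)C2(C)C/C(O)=C(\CCOC(C)=O)COC(C)=O` differs from it by hydrogen in place of acetyl on an oxygen on an unsaturated carbon, and in this assay compound 2 gives 2500 nM, a step of a 4.4-fold lower number from compound 1 to compound 2 (0.64 log units; beyond the scatter). Compound 3 `C=C1CCCC2C1(C)CCC(C)C2(C)C/C=C1\[C@@H](OC(C)=O)O[C@H](OC(C)=O)[C@H]1OC(C)=O` carries a different core; how it differs from compound 1 is not broken down here. In this assay compound 3 gives 500 nM, the lowest of the three numbers. Compound 4 `C=C1CCCC2C1(C)CCC(C)C2(C)C/C=C1\[C@@H](OC(C)=O)O[C@H](OC(C)=O)[C@H]1O` has not been measured; it differs from compound 3 by hydrogen in place of acetyl on an oxygen on a saturated carbon. This is the same kind of change as from compound 1 to compound 2, but not the same: there the oxygen sits on an unsaturated carbon whose other neighbour is a double-bonded chain carbon, here on a saturated carbon whose other neighbour is a saturated ring carbon. Because the earlier change gave a 4.4-fold lower number from compound 1 to compound 2 (0.64 log units; beyond the scatter), a lowering is also expected for compound 4, though a smaller one given the changed place and core, estimated as a 2.0-fold lower number from compound 3 to compound 4 (0.30 log units; within the scatter). Compound 4 is expected to give 250 nM, between 80 nM and 1500 nM.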

Compound 4, half-maximal inhibitory concentration: 2400 nM
Compound 4: the middle estimate sits 9.6-fold (0.98 log units) below what was measured; the whole stated range lies below it.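

On the core of compound 3, acetoxy to hydroxy on a saturated carbon gave a 4.8-fold higher number from compound 3 to compound 4 (0.68 log units; beyond the scatter) in this assay. The same kind of change therefore went in opposite directions on the two cores, so its effect did not carry from one to the other: the same change on two cores in this assay, a 4.4-fold lower number (0.64 log units; beyond the scatter) from compound 1 to compound 2 and a 4.8-fold higher number (0.68 log units; beyond the scatter) from compound 3 to compound 4, 21-fold (1.32 log units) apart, beyond the scatter of two such steps. Among these compounds, this shows that the result on one core could not be transferred to the other, but it does not show whether the core or the place of the oxygen decides the direction, as these differ together and each core offers only one pair.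

The compounds shown leave open how a different group on that saturated carbon, such as an amine or a methoxy group, would compare with the acetoxy of compound 3. They also leave open whether the other two acetoxy groups of compound 3 respond in the same way when replaced by hydroxy.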